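Swapping an aryl group on sulfur in a weak antiproliferative series

This account rests on a few compounds, and the source may have more. Where it says the series, first, only, none or still open, it means among the compounds named here.

Compound 2, with the structure `CC(O)(C[S+]([O-])c1ccccn1)C(=O)Nc1ccc([N+](=O)[O-])cc1C(F)(F)F`, sits at the edge of what a functional assay on CWR22R cells (Homo sapiens) for antiproliferative activity (a lower number here means a stronger inhibitor, a higher number a weaker inhibitor), can report: its value of > 100000 nM is a limit of the assay, not a number. Compound 1, `CC(O)(C[S+]([O-])c1ccc(F)cc1F)C(=O)Nc1ccc([N+](=O)[O-])cc1C(F)(F)F`, differs from it only in the group attached to the sulfur and in this assay gives 51100 nM. Compound 3, `CC(O)(C[S+]([O-])c1ccc(F)c(F)c1)C(=O)Nc1ccc([N+](=O)[O-])cc1C(F)(F)F`, carries yet another aryl group on that sulfur and in this assay gives > 100000 nM; > 100000 nM (2 entries), which is again a limit rather than a number. Within the data shown here, the one measured step that bears on the change under study is an at least 1.9-fold higher number from compound 1 to compound 2 (0.29 log units; that floor lies within the scatter); that change was a pyridin-2-yl in place of 2,4-difluorophenyl, and its size is known only as a floor because compound 2 reaches (the limit of > 100000 nM in this assay, at which 1 of the 3 values shown sits).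

Compound 4, `CC(O)(C[S+]([O-])c1ccccc1OC(F)(F)F)C(=O)Nc1ccc([N+](=O)[O-])cc1C(F)(F)F`, has not yet been measured. It differs from compound 2 as follows: 2-(trifluoromethoxy)phenyl in place of pyridin-2-yl on a sulfur. Reversing the kind of change seen from compound 1 to compound 2 gives no clear direction, since compound 3 with a carbon-only ring also reaches the limit. The expectation for compound 4 is therefore a step of an at least 1.2-fold lower number from compound 2 to compound 4 (0.09 log units; that floor lies within the scatter), within the scatter, and an estimated value of 80000 nM with a range from 30000 nM to 200000 nM.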

Compound 4, half-maximal inhibitory concentration: 15200 nM
For compound 4 the middle estimate is 5.3-fold (0.72 log units) above the measured one; measured number below the stated range.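

The new compound shows that the group on this sulfur can move the antiproliferative read-out by more than the usual scatter, which the earlier step could not establish. Replacing pyridin-2-yl with 2-(trifluoromethoxy)phenyl gives an at least 6.5-fold lower number from compound 2 to compound 4 (0.81 log units; beyond the scatter), so this position responds to the change in at least one case. The gain is not simply a matter of having a ring of carbon only, since compound 1 also has such a ring and the change to 2-(trifluoromethoxy)phenyl still gives a 3.4-fold lower number from compound 1 to compound 4 (0.53 log units; beyond the scatter).

How far the trifluoromethoxy group itself accounts for this remains open, and a phenyl ring with no substituent, or one carrying methoxy or trifluoromethyl, would help to separate that group from the ring that holds it. The full size of the first step also stays unknown, because compound 2 has a limit of the assay rather than a number: the limit of > 100000 nM in this assay, at which 1 of the 4 values shown sits.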